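This account rests on a few compounds, and the source may have more. Where it says the series, first, only, none or still open, it means among the compounds named here.

In a functional assay on DU-145 cells (Homo sapiens) for cytotoxicity, read by MTT assay (a higher number here means a weaker inhibitor, a lower number a stronger inhibitor), compound 2 `CC(C)=CC[C@@H](OC(=O)C1CCOC1)C1=CC(=O)c2c(O)ccc(O)c2C1=O` gives 47500 nM, which lies within the scatter of compound 1 `CCC(CO[C@H](CC=C(C)C)C1=CC(=O)c2c(O)ccc(O)c2C1=O)OC(C)=O` at 25400 nM. Compound 3 `CC(=O)OC(C)CO[C@H](CC=C(C)C)C1=CC(=O)c2c(O)ccc(O)c2C1=O` differs from compound 2 by one change: 2-acetoxypropyl in place of (oxolan-3-yl)carbonyl on an oxygen on a saturated carbon. Within the data shown here, the one measured step bearing on this, a 1.9-fold higher number from compound 1 to compound 2 (0.27 log units; within the scatter), exchanges the same (oxolan-3-yl)carbonyl with 2-acetoxybutyl on that oxygen, so no change beyond the scatter is expected in this assay. The expected step, a 1.6-fold lower number from compound 2 to compound 3 (0.20 log units; within the scatter), rests on that single comparison. For compound 3 the estimated value is 30000 nM, with an expected range of 14000 nM to 62000 nM.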

Compound 3, half-maximal inhibitory concentration: 16600 nM
Estimate against measurement, compound 3: 1.8-fold (0.26 log units) above; measured number inside the range.
By their numbers in this assay, from the lowest: compounds 3, 1 and 2 (each within the scatter of the next, the first and the last beyond it).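

In this assay, among these compounds, 2-acetoxypropyl in place of (oxolan-3-yl)carbonyl on an oxygen on a saturated carbon gives a 2.9-fold lower number from compound 2 to compound 3 (0.46 log units; beyond the scatter) as the first step at this position beyond the scatter, though a modest one. Hydrogen in place of methyl on the saturated chain carbon gives a 1.5-fold lower number from compound 1 to compound 3 (0.18 log units; within the scatter) and does not separate 2-acetoxypropyl from 2-acetoxybutyl. No measurement given here explains the gap between these groups.

Going by these compounds, whether an amine or a carboxylic acid on this oxygen would shift the number remains open. So does the effect of a chain longer than 2-acetoxybutyl.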